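This account rests on a few compounds, and the source may have more. Where it says the series, first, only, none or still open, it means among the compounds named here.

In a functional assay on MCF7 cells (Homo sapiens) for inhibition, read by MTT assay, with a stated time of 72 h (a higher number here means a weaker inhibitor, a lower number a stronger inhibitor), compound 1 `O=[N+]([O-])c1ccc(-c2nnc(SCCCN3CCN(c4nc5ccccc5o4)CC3)o2)cc1` gives 90100 nM, compound 2 `Cc1ccc(-c2nnc(SCCCN3CCN(c4nc5ccccc5o4)CC3)o2)cc1` gives 60400 nM and compound 3 `Cc1ccc(-c2nnc(SCCCN3CCN(c4nc5ccccc5s4)CC3)o2)cc1` gives 107000 nM. These values lie within the usual scatter of one another, so compound 3 cannot be set apart from the other two. Compound 4 `O=C(NCc1nnc(SCCCN2CCN(c3nc4ccccc4s3)CC2)o1)c1ccccc1` carries benzamidomethyl in place of 4-methylphenyl on an aromatic carbon. Two measured steps offer some guidance: a 1.5-fold lower number from compound 1 to compound 2 (0.17 log units; within the scatter), a swap on the aromatic group that compound 4 loses, and a 1.8-fold higher number from compound 2 to compound 3 (0.25 log units; within the scatter), a swap elsewhere. Both stayed within the scatter, but neither replaced that whole group, so the evidence is thin. No step beyond the scatter is expected, in either direction. The estimated step is a 1.5-fold lower number from compound 3 to compound 4 (0.18 log units; within the scatter). Compound 4 is therefore expected at 70000 nM, with an estimated range from 25000 nM to 160000 nM.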

Compound 4, half-maximal inhibitory concentration: 39000 nM
For compound 4 the middle estimate is 1.8-fold (0.25 log units) above the measured one, within the range that was stated.
By their numbers in this assay, from the lowest: compounds 4, 2, 1 and 3 (each within the scatter of the next, the first and the last beyond it).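

For the compounds shown here, replacing 4-methylphenyl with benzamidomethyl on this aromatic carbon gives a 2.7-fold lower number from compound 3 to compound 4 (0.44 log units; beyond the scatter) in this assay, the only step so far to pass the scatter, though a modest one. So this place accepts a larger group that keeps the six-membered aromatic ring and adds a hydrogen-bond donor and acceptor, with no loss of activity. No measurement here explains the gain.

Which part of benzamidomethyl matters remains open. An aminomethyl group, or a longer chain between the amide and the core, could help separate the contributions.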